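The source may hold more compounds than are shown below. What is called first, only, known or untested is meant among the compounds shown, and "the series" means these compounds.

In a functional assay on K562 cells (Homo sapiens) for antiproliferative activity, read by MTT assay, with a stated time of 5 days (a lower number here means a stronger inhibitor, a higher number a weaker inhibitor), compound 3 `COc1ccc(C(=Cc2ccccc2)C(=O)c2cc(OC)c(OC)c(OC)c2)cc1` has the highest number of the three measured compounds, at 4920000 nM. Compound 1 `COc1ccc(C=C(C(=O)c2cc(OC)c(OC)c(OC)c2)c2ccc(C)cc2)cc1[N+](=O)[O-]` gives 2430000 nM, and compound 2 `COc1ccc(C=C(C(=O)c2cc(OC)c(OC)c(OC)c2)c2ccc(C)cc2)cc1F` gives 570000 nM.

Compound 4 `COc1cc(C(=O)C(=Cc2ccccc2)c2ccc(C)cc2)cc(OC)c1OC` differs from compound 3 by a single exchange, methyl in place of methoxy on an aromatic carbon, para to a large group: methyl in place of methoxy on an aromatic carbon. In other words, 4-methoxyphenyl becomes 4-methylphenyl.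

Among the measured compounds shown here, no measured pair shows this exchange directly. For the measured compounds named here, the only measured step is a 4.3-fold lower number from compound 1 to compound 2 (0.63 log units; beyond the scatter), which is fluoro in place of nitro on an aromatic carbon, a different exchange at a different place. It shows that one exchange can shift the number modestly in these compounds, but it gives no direction for methoxy and methyl. Compounds 1 and 2 both carry 4-methylphenyl, but they also differ from compound 4 elsewhere.

No clear step beyond the scatter is therefore expected in this assay. The expected change is a 1.2-fold lower number from compound 3 to compound 4 (0.09 log units; within the scatter). Compound 4 is estimated at 4000000 nM, with an expected range from 1300000 nM to 12000000 nM.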

Compound 4, half-maximal inhibitory concentration: 2970000 nM
The estimate for compound 4 lay 1.3-fold (0.13 log units) above the measured number; low and high end bracket the measured number.
By their numbers in this assay, from the lowest: compound 2; then compounds 1, 4 and 3 (each within the scatter of the next, the first and the last beyond it).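

In this assay, among the compounds shown here, the step of a 1.7-fold lower number from compound 3 to compound 4 (0.22 log units; within the scatter) is the first direct reading of 4-methoxyphenyl changing to 4-methylphenyl, and at this position the exchange gives no clear shift. The other aromatic group matters more in one case: phenyl in place of 3-fluoro-4-methoxyphenyl gives a 5.2-fold higher number from compound 2 to compound 4 (0.72 log units; beyond the scatter), beyond the scatter, whereas phenyl in place of 4-methoxy-3-nitrophenyl gives a 1.2-fold higher number from compound 1 to compound 4 (0.09 log units; within the scatter), within it. No supporting measurement is available to explain either result.

On these data alone, only methoxy and methyl have been compared at the position para to a large group, so it remains open whether an amine, a hydroxyl or a chloro group there would move the number beyond the scatter. As far as these compounds go, it is also open whether the step seen with 3-fluoro-4-methoxyphenyl would persist alongside 4-methoxyphenyl instead of 4-methylphenyl.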